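Adding a second methoxy group to compound 3

The source may report more compounds than this note shows. Statements on the series, on what has been measured and on what is new or still open speak of the compounds shown alone.

Measured so far in a functional assay on A549 cells (Homo sapiens) for cytotoxicity, read by MTT assay, with a stated time of 48 h; a higher number here means a weaker inhibitor, a lower number a stronger inhibitor:
compound 1 `COc1ccc(-c2cc(C(=O)Nc3nc4ccccc4s3)nc3cc(-c4ccccc4)nn23)cc1OC` gives 5490 nM;
compound 2 `Cc1cc2nc(NC(=O)c3cc(-c4ccc(F)cc4)n4nc(-c5ccccc5)cc4n3)sc2cc1C` gives 12600 nM;
compound 3 `COc1ccc(-c2cc(C(=O)Nc3nc4cc(C)c(C)cc4s3)nc3cc(-c4ccccc4)nn23)cc1` gives 13200 nM.

Compound 3 has the highest number of the three, within the scatter of compound 2 and beyond it relative to compound 1. Compound 4 `COc1ccc(-c2cc(C(=O)Nc3nc4cc(C)c(C)cc4s3)nc3cc(-c4ccccc4)nn23)cc1OC` differs from compound 3 by methoxy in place of hydrogen on an aromatic carbon. Among the measured compounds shown here, no measured step changes exactly this; the only measured step, a 1.0-fold higher number from compound 2 to compound 3 (0.02 log units; within the scatter), concerns a different exchange at that ring and lies within the scatter. Compound 1 carries the same two methoxy groups as compound 4 but lacks the two methyl groups of compound 3, so its lower number cannot be assigned to one change. Compound 4 is therefore expected near compound 3, perhaps somewhat lower, estimated at 9000 nM with a range of 3500 nM to 23000 nM, a step of a 1.5-fold lower number from compound 3 to compound 4 (0.17 log units; within the scatter).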

Compound 4, half-maximal inhibitory concentration: 2950 nM
Compound 4: the middle estimate sits 3.1-fold (0.48 log units) above what was measured; measured number below the stated range.
By their numbers in this assay, from the lowest: compounds 4 and 1 (each within the scatter of the next); then compounds 2 and 3 (each within the scatter of the next).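

In this assay, with the 5,6-dimethyl-1,3-benzothiazol-2-yl group held fixed, going from 4-methoxyphenyl to 3,4-dimethoxyphenyl gives a 4.5-fold lower number from compound 3 to compound 4 (0.65 log units; beyond the scatter), and replacing 4-fluorophenyl gives a 4.3-fold lower number from compound 2 to compound 4 (0.63 log units; beyond the scatter), so this ring position responds where the earlier exchange of fluoro for methoxy did not. Changing 1,3-benzothiazol-2-yl to 5,6-dimethyl-1,3-benzothiazol-2-yl gives only a 1.9-fold lower number from compound 1 to compound 4 (0.27 log units; within the scatter), so with 3,4-dimethoxyphenyl present the two methyl groups make no readable difference. Nothing available explains why the added methoxy matters.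

Going by these compounds, whether an ethoxy, a hydroxyl or an amine at the same place would do as well remains open.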